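Quinoline thiosemicarbazones: terminal nitrogen substituent and antiproliferative potency

This account rests on a few compounds, and the source may have more. Where it says the series, first, only, none or still open, it means among the compounds named here.

Measured compounds:
compound 1 `CN(C)C(=S)N/N=C/c1ccc2ccccc2n1`: 20 nM
compound 2 `N#Cc1ccc(NC(=S)N/N=C/c2ccc3ccccc3n2)cc1`: 15600 nM
compound 3 `S=C(N/N=C/c1ccc2ccccc2n1)Nc1cccc(Br)c1`: 58900 nM

All three were run in a functional assay on HT-29 cells (Homo sapiens) for antiproliferative activity, read by sulforhodamine B assay, with a stated time of 72 h; a lower number here means a stronger inhibitor, a higher number a weaker inhibitor. Compound 3 gives the highest number of the three. For the measured compounds named here, its nearest neighbour is compound 2, separated by the only one-place step measured so far, a 3.8-fold higher number from compound 2 to compound 3 (0.58 log units; beyond the scatter), an exchange of one aryl group for another on the amide-type nitrogen. Going by the values given here, compound 1, which carries two methyl groups on that nitrogen, stands far lower than either; no single step connects it to compound 3, but the two values together show that the number moves over a very wide span with what this nitrogen bears.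

Compound 4 `NC(=S)N/N=C/c1ccc2ccccc2n1` is the next step: hydrogen in place of 3-bromophenyl on an amide-type nitrogen. Among the compounds with values here, no measured step removes an aryl group from this nitrogen outright, so the modest aryl-for-aryl step is the only direct guide, and it cannot set the size. Because compound 1 gives 20 nM while compound 3 gives 58900 nM, a move toward the smaller substituent is expected to lower the number substantially, though how far is uncertain. The expected step for compound 4 is a 29-fold lower number from compound 3 to compound 4 (1.47 log units; beyond the scatter). Compound 4 is estimated at 2000 nM, in the range 200 nM to 20000 nM.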

Compound 4, half-maximal inhibitory concentration: 100000 nM
The estimate for compound 4 lay 50-fold (1.70 log units) below the measured number; the measured number lies above the stated range.
By their numbers in this assay, from the lowest: compound 1; then compound 2; then compounds 3 and 4 (each within the scatter of the next).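

Taking the aryl group off this nitrogen does not bring the series toward compound 1: hydrogen in place of 3-bromophenyl gives (a 1.7-fold higher number from compound 3 to compound 4 (0.23 log units; within the scatter)), so a smaller substituent alone does not account for the low number of compound 1. Hydrogen in place of 4-cyanophenyl gives (a 6.4-fold higher number from compound 2 to compound 4 (0.81 log units; beyond the scatter)), a modest step that leaves compound 4 no closer to compound 1. The large step is the one from the two methyl groups to the bare amino group (a 5000-fold higher number from compound 1 to compound 4 (3.70 log units; beyond the scatter)), so here the span depends on the dimethylamino end itself rather than on the absence of an aryl group.

No measurement among these data explains this difference. On these data alone, whether one methyl group, a diethylamino group or a piperidine ring on the thiocarbonyl carbon keeps the number of compound 1 remains open.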